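The compounds below may be only part of what the source reports. "The series", "measured", "known", "first", "only" and "open" are said of these compounds alone.

Measured in a functional assay on HCT-15 cells (Homo sapiens) for cytotoxicity, read by ELISA, with a stated time of 2 days; on this read-out lower numbers stand for stronger inhibition and higher numbers for weaker inhibition:
- compound 1 `Oc1ccc(-c2cc(-c3ccccc3)cc(-c3cccs3)n2)cc1`: 12500 nM
- compound 2 `Oc1ccc(-c2cc(-c3ccccc3)cc(-c3ccsc3)n2)cc1`: 1100 nM
- compound 3 `Oc1ccc(-c2cc(-c3ccccc3)cc(-c3ccco3)n2)cc1`: 3500 nM

Compound 3 holds the middle place among the three numbers. It is clearly separated from both other compounds: a 3.2-fold higher number from compound 2 to compound 3 (0.50 log units; beyond the scatter), and a 3.6-fold lower number from compound 1 to compound 3 (0.55 log units; beyond the scatter).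

The next compound, compound 4 `Oc1ccc(-c2cc(-c3ccccc3)cc(-c3ccc(O)cc3)n2)cc1`, carries 4-hydroxyphenyl in place of furan-2-yl on an aromatic carbon, next to the ring nitrogen: 4-hydroxyphenyl in place of furan-2-yl on an aromatic carbon.

All three measured steps are exchanges at this same place, so all of them bear on the change. The largest is an 11-fold lower number from compound 1 to compound 2 (1.06 log units; beyond the scatter), which shows that even a swap between two thiophene attachments can move the number well beyond the scatter. The other two are modest: a 3.6-fold lower number from compound 1 to compound 3 (0.55 log units; beyond the scatter) and a 3.2-fold higher number from compound 2 to compound 3 (0.50 log units; beyond the scatter). Within the data shown here, none of the measured compounds has a six-membered ring at this place, and the direction of the step cannot be read from the series. With no firm direction, the expectation in this assay is for no step beyond the scatter, with a wide margin on either side. The estimated step is a 1.1-fold higher number from compound 3 to compound 4 (0.06 log units; within the scatter). For compound 4 the expected value is 4000 nM, with an estimated range of 1000 nM to 16000 nM.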

Compound 4, half-maximal inhibitory concentration: 3000 nM
Compound 4: middle estimate off by 1.3-fold (0.12 log units), on the high side; the range from low to high includes it.
By their numbers in this assay, from the lowest: compound 2; then compounds 4 and 3 (each within the scatter of the next); then compound 1.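

In this assay, the first six-membered aromatic ring of carbon only at this place, 4-hydroxyphenyl, cannot be told apart from furan-2-yl (a 1.2-fold lower number from compound 3 to compound 4 (0.07 log units; within the scatter)), so neither the change of ring size nor the added hydrogen-bond donor moves the number beyond the scatter in this pair. The same group stays clearly separated from both thiophene attachments, in opposite directions (a 2.7-fold higher number from compound 2 to compound 4 (0.44 log units; beyond the scatter); a 4.2-fold lower number from compound 1 to compound 4 (0.62 log units; beyond the scatter)), which leaves thiophen-3-yl with the lowest number and thiophen-2-yl with the highest of the four groups, and shows that ring size alone does not sort the series. Nothing on hand accounts for this order of the groups.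

The compounds shown leave open whether the hydroxyl on the 4-hydroxyphenyl group matters at all: a plain phenyl or a 4-methoxyphenyl at this place would separate the effect of the ring from that of its substituent. Also open, as far as these compounds go, is whether a pyridin-3-yl ring, or a phenyl ring bearing an amine or a carboxylic acid, would reach or pass the number of compound 2.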